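Hydroxy to Fluoro: Expected Tolerance of Compound 3

The compounds below may be only part of what the source reports. "The series", "measured", "known", "first", "only" and "open" are said of these compounds alone.

Among the compounds with values here, compound 1 `Nc1ccn([C@@H]2O[C@H](CO)[C@](O)(CO)[C@H]2O)c(=O)n1` is the only compound of this set with a measured number in an ADME assay on Huh-7 cells (Homo sapiens) for cytotoxicity, read by WST assay, with a stated time of 3 days; a higher number here means that more compound is tolerated, a lower number that less compound is tolerated; in this assay compound 1 gives 12300 nM. The other measured compound, compound 2 `Nc1ccnc2c1ncn2[C@@H]1O[C@H](CO)[C@](O)(CF)[C@H]1O`, is built on a different core. In this assay compound 2 reaches only a limit of the assay, > 100000 nM. Within the data shown here, no step between two measured compounds can be drawn, so compound 1 stands alone as the sole number, with one further value sitting at the limit of > 100000 nM in this assay, at which 1 of the 2 values shown sits.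

Compound 3 `Nc1ccn([C@@H]2O[C@H](CO)[C@](O)(CF)[C@H]2O)c(=O)n1` differs from compound 1 by fluoro in place of hydroxy on a saturated chain carbon bound to a saturated ring carbon; cut one bond further out, the same difference reads hydroxymethyl to fluoromethyl. Compound 2 carries the fluoromethyl as well. Because compound 2 sits at the limit of > 100000 nM in this assay, at which 1 of the 2 values shown sits, the fluoromethyl is tolerated up to the top of the range on that core, though nothing ties the two cores together. The step of a 2.8-fold higher number from compound 1 to compound 3 (0.45 log units; beyond the scatter) is therefore expected to run toward a more tolerated compound, beyond the usual scatter but not with certainty. Compound 3 is estimated at 35000 nM, with a range from 8000 nM to 150000 nM in this assay.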

Compound 3, half-maximal cytotoxic concentration: > 100000 nM
Compound 3: a limit, no number (the forecaster's own chance of this, stated with the estimate: 40%); middle value at least 2.8-fold (0.45 log units) from the limit.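

Within the data shown here, for the first time, the change from hydroxymethyl to fluoromethyl can be read on one core, and in this assay it gives an at least 8.1-fold higher number from compound 1 to compound 3 (0.91 log units; beyond the scatter), so hydroxy is not required for tolerance at this place, on a saturated chain carbon bound to a saturated ring carbon; the earlier compounds offered no such pair. In this assay, as far as these compounds go, compound 3 gives > 100000 nM, which is a limit of the assay and not a number, so the step fixes only a lower bound and its true size stays unknown. With this result, compound 1 remains the only compound with a number, and the upper end of the range now holds most of the compounds shown: the limit of > 100000 nM in this assay, at which 2 of the 3 values shown sit.

The compounds shown leave open whether an aminomethyl, a methoxymethyl or a longer chain on this carbon would be tolerated as well as the fluoromethyl, or would fall closer to the hydroxymethyl of compound 1. Among these compounds, they also leave open whether the same change would read the same way on the core of compound 2, as no pair on that core stands among them.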